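Bromo to iodo on the phenoxy ring

A few compounds are considered here, and "the series" means these few. Any claim that something is new, unique, unknown or untested is made for them only; others in the source may bear on it.

For the measured compounds named here, in a functional assay on U-87MG ATCC cells for antiproliferative activity against U-87 MG (Homo sapiens), read by MTT assay, with a stated time of 72 h (a lower number here means a stronger inhibitor, a higher number a weaker inhibitor), compound 2 `Cc1nn(C)c(Oc2ccc(Br)cc2)c1/C=N\CCCCCOc1cc2oc(=O)cc(C)c2cc1Cl` gives 15300 nM, the only number in the pair. Compound 1 `Cc1nn(C)c(Oc2ccc(F)cc2)c1/C=N\CCCCCOc1cc2oc(=O)cc(C)c2cc1Cl` sits at a limit, > 25000 nM, which is a limit and not a number (the limit of > 25000 nM in this assay, at which 1 of the 2 values shown sits). Going by the values given here, the single measured step, an at least 1.6-fold lower number from compound 1 to compound 2 (0.21 log units; that floor lies within the scatter), is a floor inside the scatter. Compound 3 `Cc1nn(C)c(Oc2ccc(I)cc2)c1/C=N\CCCCCOc1cc2oc(=O)cc(C)c2cc1Cl` differs from compound 2 by iodo in place of bromo on an aromatic carbon. Among the compounds with values here, only that fluoro-to-bromo step bears on it, and its size is unresolved, so no step beyond the scatter is expected, with at most a slight lean toward a lower number. Compound 3 is expected near 10000 nM (range 4000 nM to 25000 nM), the expected step being a 1.5-fold lower number from compound 2 to compound 3 (0.18 log units; within the scatter).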

Compound 3, half-maximal inhibitory concentration: > 25000 nM
Compound 3: only a limit was reported; the forecaster's own chance of this, stated with the estimate: 25%; middle value at least 2.5-fold (0.39 log units) from the limit.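

In this assay, iodo in place of bromo gives an at least 1.6-fold higher number from compound 2 to compound 3 (0.21 log units; that floor lies within the scatter), so the lean toward a lower number seen in the fluoro-to-bromo step does not continue to iodo, though neither floor clears the scatter. Compound 3 is reported only as a limit, and the halogen series at this position now has a single number, that of compound 2. The step between compound 1 and compound 3 cannot be read, because both values are limits: the limit of > 25000 nM in this assay, at which 2 of the 3 values shown sit.

Still open, on these data alone, is whether an amine or a carboxylic acid on this aromatic carbon would give a clearly lower number. As far as these compounds go, the effect of a longer chain in the shared core also remains open.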